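A few compounds are considered here, and "the series" means these few. Any claim that something is new, unique, unknown or untested is made for them only; others in the source may bear on it.

Measured compounds:
compound 1, `COc1ccccc1S(=O)(=O)/C=C/c1ccccn1`, 9070 nM
compound 2, `COc1ccccc1S(=O)(=O)/C=C/c1cccc(Cl)n1`, 1160 nM
compound 3, `COc1ccccc1S(=O)(=O)/C=C/c1ncccc1Cl`, 142 nM

In an assay on U2OS cells for activation of nuclear factor erythroid 2-related factor 2 (Homo sapiens), read by chemiluminescence, with a stated time of 6 h (on this read-out lower numbers stand for an effect already at smaller amounts and higher numbers for an effect only at larger amounts of compound), compound 1 gives the highest of the three numbers. Its nearest neighbour is compound 2, reached through a 7.8-fold lower number from compound 1 to compound 2 (0.89 log units; beyond the scatter); the furthest is compound 3, reached through a 64-fold lower number from compound 1 to compound 3 (1.81 log units; beyond the scatter). Compound 4, `COc1ccccc1S(=O)(=O)/C=C/c1cncnc1`, has not yet been measured. It differs from compound 1 by pyrimidin-5-yl in place of pyridin-2-yl on a double-bonded chain carbon bound to a double-bonded chain carbon.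

Both measured steps place chloro on an aromatic carbon of the ring attached to the chain; neither exchanges one ring for another, so neither bears directly on the change to compound 4. Within the data shown here, the series shows only that this ring is a sensitive position, where a single change moved the number by a modest to large amount. Among the measured compounds shown here, with no precedent for a ring swap, the step from compound 1 to compound 4 in this assay is expected to be small, in either direction, and may stay within the scatter; the estimate is a 1.3-fold higher number from compound 1 to compound 4 (0.12 log units; within the scatter). Compound 4 is therefore estimated at 12000 nM, within a range from 3000 nM to 50000 nM.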

Compound 4, half-maximal effective concentration: > 10000 nM
Compound 4 gave a limit, no number; the forecaster's own chance of this, stated with the estimate: 20%; the middle value is on the limit's open side.
By their numbers in this assay, from the lowest: compound 3; then compound 2; then compound 1. At a limit, above all of these: compound 4.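

In this assay compound 4 gives > 10000 nM as a limit of the assay and not a number. The exchange of one ring for another, pyrimidin-5-yl in place of pyridin-2-yl on a double-bonded chain carbon bound to a double-bonded chain carbon, thus brought no lower number, whereas both chloro steps on the pyridin-2-yl ring did. The step is an at least 1.1-fold higher number from compound 1 to compound 4 (0.04 log units; that floor lies within the scatter) and so shows only a floor, which leaves it undecided whether compound 4 truly departs from compound 1.

On these data alone, how far beyond the limit compound 4 lies remains open. Also open, as far as these compounds go, is whether chloro on the pyrimidin-5-yl ring would lower the number as it did on pyridin-2-yl, and what an amine or a carboxylic acid on this ring would do.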